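The compounds below may be only part of what the source reports. "The series", "measured", "known", "first", "only" and "open" are said of these compounds alone.

Compound 1 `COc1ccc(S(=O)(=O)Nc2cc(Cl)c(Cl)cc2Cl)cc1N1CCNCC1`: 5.01 nM
Compound 2 `COc1ccc(S(=O)(=O)Nc2cc(Br)cc(Br)c2Cl)cc1N1CCNCC1`: 2.51 nM

Both compounds share a core that carries a sulfonamide nitrogen bearing a halogenated phenyl ring, and both were tested in an assay on isolated protein for binding affinity to 5-hydroxytryptamine receptor 6 (Homo sapiens); on this read-out lower numbers stand for stronger inhibition and higher numbers for weaker inhibition. Compound 1 gives 5.01 nM in this assay, and compound 2 gives 2.51 nM. Among these two numbers compound 2 has the lowest, but the single measured step, a 2.0-fold lower number from compound 1 to compound 2 (0.30 log units; within the scatter), lies within the scatter, so the two compounds cannot be told apart on this evidence.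

Compound 3 `COc1ccc(S(=O)(=O)Nc2cc(Br)cc(F)c2Cl)cc1N1CCNCC1` is not yet measured. It differs from compound 2 in one place: fluoro in place of bromo on an aromatic carbon. Among the compounds with values here, the only step that bears on this change is a 2.0-fold lower number from compound 1 to compound 2 (0.30 log units; within the scatter), where the halogen pattern on the same ring was rearranged with no effect beyond the scatter. Nothing is known here about a fluoro group on this ring. The expectation is therefore a small step of a 1.6-fold higher number from compound 2 to compound 3 (0.20 log units; within the scatter), perhaps toward a slightly higher number, but not clearly beyond the scatter. Compound 3 is estimated to give 4 nM in this assay, with a likely range from 1.5 nM to 12 nM.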

Compound 3, inhibition constant: 3.16 nM
Estimate against measurement, compound 3: 1.3-fold (0.10 log units) above, within the range that was stated.
By their numbers in this assay, from the lowest: compounds 2, 3 and 1 (each within the scatter of the next).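

Replacing bromo with fluoro, on an aromatic carbon ortho to a chloro group and meta to a bromo group, isolates a single halogen at one position, and in this assay this gives a 1.3-fold higher number from compound 2 to compound 3 (0.10 log units; within the scatter) with no difference that can be read. On this evidence the position carries either a large bromo or a small fluoro without a detectable change in the number, which the earlier rearrangement of several halogens at once could not show. Compared with the 2,4,5-trichlorophenyl group, the 5-bromo-2-chloro-3-fluorophenyl group gives a 1.6-fold lower number from compound 1 to compound 3 (0.20 log units; within the scatter) and so also stays inside the scatter, and no measurement at hand offers an explanation for these closely matched results.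

Every compound shown carries only halogens on this ring, so the effect of an amine, a methoxy group or a carboxylic acid at this position remains open. Within the data shown here, also open is whether a plain hydrogen there would produce a step beyond the scatter, as all the steps so far lie within it.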